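Methoxy Added to Compound 1: What to Expect

A few compounds are considered here, and "the series" means these few. Any claim that something is new, unique, unknown or untested is made for them only; others in the source may bear on it.

Measured compounds:
Compound 1 `COc1ccc(-c2[nH]c3ccccc3c2/C=C(\C#N)S(=O)(=O)c2ccccc2)cc1`: 1200 nM
Compound 2 `CCOC(=O)C(=Cc1c(-c2ccccc2)[nH]c2ccccc12)C(=O)OCC`: 12900 nM

In a functional assay on 786-0 cells (Homo sapiens) for inhibition, read by sulforhodamine B assay, with a stated time of 48 h (a higher number here means a weaker inhibitor of growth, a lower number a stronger inhibitor of growth), compound 1 gives 1200 nM, the lowest of the two numbers shown. Compound 2 gives 12900 nM, a gap that lies beyond the scatter. Compound 3 `COc1ccc(-c2[nH]c3ccc(OC)cc3c2/C=C(\C#N)S(=O)(=O)c2ccccc2)cc1` differs from compound 1 by methoxy in place of hydrogen on an aromatic carbon. Among the measured compounds shown here, no measured pair shows such a change, so the estimated step is a 1.2-fold lower number from compound 1 to compound 3 (0.08 log units; within the scatter), at most a small move toward a lower number, within the scatter. Compound 3 is expected to give about 1000 nM, between 350 nM and 3000 nM.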

Compound 3, concentration for 50% growth inhibition: 2100 nM
Compound 3: middle estimate off by 2.1-fold (0.32 log units), on the low side; measured number inside the range.
By their numbers in this assay, from the lowest: compounds 1 and 3 (each within the scatter of the next); then compound 2.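

Methoxy in place of hydrogen on this aromatic carbon gives a 1.8-fold higher number from compound 1 to compound 3 (0.24 log units; within the scatter) in this assay. Among the compounds shown here, this is the first pair here that differs in one place, and it shows that this position can carry methoxy with no change that stands out from the scatter. Nothing measured here offers an explanation for this result.

From the compounds shown here alone, whether an amine, a carboxylic acid or a longer chain at this position would behave the same way remains open. One pair also cannot show how methoxy would behave on other carbons of the core.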